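A few compounds are considered here, and "the series" means these few. Any claim that something is new, unique, unknown or untested is made for them only; others in the source may bear on it.

Compound 1 `Oc1cccc(-c2cc(-c3ccccc3)cc(-c3ccco3)n2)c1` and compound 2 `Oc1ccc(-c2cc(-c3ccccc3)cc(-c3ccco3)n2)cc1` share one core and differ in a single place. In an assay on isolated protein for inhibition of DNA topoisomerase 1 (Homo sapiens), with a stated time of 30 min, tested at 100 uM (a higher number here means a stronger effect of the compound at the concentration tested, a lower number a weaker effect), compound 1 gives 10.2%, while compound 2 gives 18.6%. The change between them, (4-hydroxyphenyl in place of 3-hydroxyphenyl on an aromatic carbon), made a step of a number 8.4 percentage points higher from compound 1 to compound 2 (within the scatter). Compound 3 `Oc1cccc(-c2cc(-c3ccccc3)nc(-c3ccco3)c2)c1` is built on a differently joined core; how the two cores differ is not broken down here. In this assay compound 3 gives 48.8%. Compound 4 `Oc1ccc(-c2cc(-c3ccccc3)nc(-c3ccco3)c2)cc1` carries the same kind of change as compound 2, (4-hydroxyphenyl in place of 3-hydroxyphenyl on an aromatic carbon), though here the place is opposite the ring nitrogen rather than next to the ring nitrogen. Because the earlier step of a number 8.4 percentage points higher from compound 1 to compound 2 (within the scatter) stayed within the scatter, a similarly small step is expected here, a number 4.2 percentage points higher from compound 3 to compound 4 (within the scatter). Compound 4 is therefore estimated at 53%, expected to fall between 35% and 70%.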

Compound 4, a percentage reported as inhibition, at one concentration (the size of the read-out at that concentration, not a potency): 5%
Compound 4: the middle estimate sits 48 percentage points above what was measured; the whole stated range lies above it.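

In this assay the swap of 3-hydroxyphenyl for 4-hydroxyphenyl opposite the ring nitrogen gave a number 43.8 percentage points lower from compound 3 to compound 4 (beyond the scatter) and so cost compound 3 most of its read-out. The same change therefore does not carry over unchanged from one core to the other: the same change on two cores in this assay, a number 8.4 percentage points higher (within the scatter) from compound 1 to compound 2 and a number 43.8 percentage points lower (beyond the scatter) from compound 3 to compound 4, 52.2 percentage points apart, beyond the scatter of two such steps. This rests on a single pair of compounds per core, tested at one concentration, so it shows that the outcome depends on the core but not why, and it offers no rule for any further core.

The compounds shown leave open how other groups in this place would behave, such as an amine or a carboxylic acid in place of the hydroxyl. They also leave open whether changing the furan-2-yl or phenyl groups would alter the result.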